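Cytotoxicity Outlook for a Thiophene Analogue

The source may report more compounds than this note shows. Statements on the series, on what has been measured and on what is new or still open speak of the compounds shown alone.

Compound 1 `CC(C)N(Cc1cccc(OCCCCCC(=O)O)c1)C(=O)c1ccc(-c2ccncc2)cc1` and compound 2 `CC(C)COc1cccc(-c2ccc(C(=O)N(Cc3cccc(OCCCCCC(=O)O)c3)C(C)C)cc2)c1` share one core and differ at a single aromatic carbon. In an ADME assay on HEK293 cells (Homo sapiens) for cytotoxicity, read by CellTiter-Glo and resazurin assay, with a stated time of 72 h (a lower number here means that less compound is needed, a higher number that more compound is needed for the effect), compound 1 gives only a limit of the assay, > 26000 nM. In this assay compound 2 likewise gives only a limit of the assay, > 26000 nM. The step that the two limits leave unreadable from compound 1 to compound 2 cannot be given a size, since both values sit at the same limit (the limit of > 26000 nM in this assay, at which 2 of the 2 values shown sit). Compound 2 therefore stands at the limit in this assay, with no number that would set it apart from compound 1.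

Compound 3 `CC(C)N(Cc1cccc(OCCCCCC(=O)O)c1)C(=O)c1ccc(-c2ccsc2)cc1` differs from compound 2 in one place: thiophen-3-yl in place of 3-(isobutoxy)phenyl on an aromatic carbon. For the measured compounds named here, the only measured step offers no readable size, so nothing in the data points to a direction for this change. Compound 3 is accordingly expected to sit at the limit as well in this assay, with an estimate of 30000 nM and a range from 15000 nM to 100000 nM. The expected step that the limit leaves unreadable from compound 2 to compound 3 is thus estimated to be none beyond the scatter.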

Compound 3, half-maximal effective concentration: > 26000 nM
Compound 3: a limit, no number; the forecaster's own chance of this, stated with the estimate: 80%; the middle value does not contradict the limit.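

In this assay compound 3 gives only a limit of the assay, > 26000 nM. For the compounds shown here, no step among compound 1, compound 2 and compound 3 can be read, since all three sit at one limit: the limit of > 26000 nM in this assay, at which 3 of the 3 values shown sit. The compounds shown leave open whether any of the three has a measurable effect on these cells, and how they would rank.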